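The source may hold more compounds than are shown below. What is called first, only, known or untested is meant among the compounds shown, and "the series" means these compounds.

Measured so far:
Compound 1 `CC1(C(c2ccccc2)c2ccccc2)OS(=O)(=O)C=C1OCc1ccccc1` gives 200000 nM in an ADME assay on HEL cells (Homo sapiens) for cytotoxicity, with a stated time of 3 days; a higher number here means that more compound is tolerated, a lower number that less compound is tolerated.
Compound 2 `CCC1(Cc2ccccc2)OS(=O)(=O)C=C1OC` gives > 200000 nM in this assay, which is a limit of the assay rather than a number.

Within the data shown here, compound 1 thus stands at the only number given in this assay; the other entry is the limit of > 200000 nM in this assay, at which 1 of the 2 values shown sits. Compound 3 `CC1(Cc2ccccc2)OS(=O)(=O)C=C1OCc1ccccc1` differs from compound 1 by hydrogen in place of phenyl on a saturated chain carbon bound to an aromatic carbon and a saturated ring carbon. Among the measured compounds shown here, with no measured step to lean on, the expected change is none beyond the usual scatter, no change at the digits printed from compound 1 to compound 3 (within the scatter). Compound 3 is therefore estimated at 200000 nM, within 100000 nM to 400000 nM.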

Compound 3, half-maximal cytotoxic concentration: 68000 nM
Compound 3: the middle estimate sits 2.9-fold (0.47 log units) above what was measured, and the stated range ends above it.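

Among these compounds, compound 1 and compound 3 differ in one place only, so they give the first direct reading of a change on this saturated chain carbon bound to an aromatic carbon and a saturated ring carbon. In this assay, hydrogen in place of phenyl brings a 2.9-fold lower number from compound 1 to compound 3 (0.47 log units; beyond the scatter) and so a modest drop in the amount of compound tolerated. Nothing measured here gives a reason for this step.

The compounds shown leave open whether a methyl group or an amine on this carbon would fall nearer compound 1 or compound 3.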